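The compounds below may be only part of what the source reports. "The series", "measured", "known", "first", "only" and "open" are said of these compounds alone.

In an assay on Sf9 cells for inhibition of protein deacetylase HDAC6 (Homo sapiens), read by fluorescence, with a stated time of 40 min, tested at 100 nM (a higher number here means more inhibition at the concentration tested (going by the name of the read-out), a lower number less inhibition), three compounds have been measured. Compound 1 `COc1ccc(-n2nc(-c3ccccc3)nc2CNc2ccc(C(=O)NO)cc2)cc1` gives 63.4%, compound 2 `O=C(NO)c1ccc(NCc2nc(-c3ccccn3)nn2-c2ccccc2)cc1` gives 58.6%, and compound 3 `CNC(=O)c1ccc(NCc2nc(-c3ccccc3)nn2-c2ccccc2)cc1` gives -3.6%. Compound 2 stands second highest of these three numbers: its nearest neighbour is compound 1, whose number is higher by an amount within the usual scatter, and its furthest is compound 3, whose number is lower by an amount well beyond the scatter. Among the compounds with values here, compound 3 differs from compound 2 in more than one place, so no single step between measured compounds is available to guide the next change.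

Compound 4 `CCc1ccc(-c2nc(CNc3ccc(C(=O)NO)cc3)n(-c3ccccc3)n2)cc1` has not yet been measured in this assay. It differs from compound 2 as follows: 4-ethylphenyl in place of pyridin-2-yl on an aromatic carbon. The hydroxamic acid and the rest of the core are kept, and compound 1 shows that a phenyl group at a comparable place of the core is compatible with a number like 63.4%. Within the data shown here, no step of this kind is known, so the step of a number 3.4 percentage points higher from compound 2 to compound 4 (within the scatter) is expected to be small and not beyond the scatter, in either direction. Compound 4 is therefore estimated to give 62% in this assay, within a range from 45% to 78%.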

Compound 4, a percentage reported as inhibition, at one concentration (the size of the read-out at that concentration, not a potency): 54.6%
For compound 4 the middle estimate is 7.4 percentage points above the measured one, within the range that was stated.
By their numbers in this assay, from the lowest: compound 3; then compounds 4, 2 and 1 (each within the scatter of the next).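

In this assay, within the data shown here, placing 4-ethylphenyl in place of pyridin-2-yl on the aromatic carbon between two ring nitrogen atoms gives (a number 4 percentage points lower from compound 2 to compound 4 (within the scatter)), so this position accepts an entering group of 8 heavy atoms in place of one of 6 with no step that stands out from the scatter. The step also removes the ring nitrogen of pyridin-2-yl, the one hydrogen-bond acceptor of the leaving group, and compound 4 still reads 54.6%, so that acceptor is not needed at this position for a number of this size at the concentration tested. Nothing measured here explains why the two compounds read alike.

This single step changes the ring and adds the ethyl group at once, so the compounds shown cannot separate the part each plays, and a single-concentration reading does not give a potency for either compound. They also leave open how this position would respond to a carboxylic acid or an amine on the phenyl ring, or to a longer chain in place of the ethyl group.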